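A Small Chain Change to Compound 1

The compounds below may be only part of what the source reports. "The series", "measured", "known", "first", "only" and "open" are said of these compounds alone.

In an assay on SW1353 cells (Homo sapiens) for inhibition, read by a luciferase reporter, with stated times of 30 min and 8 h (a higher number here means a weaker inhibitor, a lower number a stronger inhibitor), three compounds have been measured so far. Compound 1 `O=c1sc2ccccc2n1CCCCCCN1CCN(CCCCCCn2c(=O)sc3ccccc32)CC1` gives 410 nM, the lowest of the three numbers. Compound 3 `O=c1sc2ccccc2n1CCCCN1CCN(CCCn2c(=O)sc3ccccc32)CC1` gives 1710 nM and compound 2 `O=c1oc2ccccc2n1CCCCCN1CCN(CCn2c(=O)oc3ccccc32)CC1` gives 4780 nM, and the gaps from both to compound 1 lie beyond the scatter of repeated measurements.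

Compound 4 `O=c1sc2ccccc2n1CCCCCCN1CCN(CCCCCn2c(=O)sc3ccccc32)CC1` has not yet been measured. It differs from compound 1 in one place, on a saturated chain carbon, five bonds along the chain from an amine nitrogen in a ring: a group of 10 heavy atoms (7 carbon, 1 nitrogen, 1 oxygen, 1 sulfur; one five-membered aromatic ring with 2 hetero atoms, one six-membered aromatic ring of carbon only) in place of a group of 11 heavy atoms (8 carbon, 1 nitrogen, 1 oxygen, 1 sulfur; one five-membered aromatic ring with 2 hetero atoms, one six-membered aromatic ring of carbon only), on a saturated chain carbon, five bonds along the chain from an amine nitrogen in a ring. Within the data shown here, no measured pair shows a change of this kind, so its size cannot be read directly from the data. Compound 1 already has the lowest number at 410 nM, so a modest move toward a weaker inhibitor is expected. The estimated change is small, a 1.5-fold higher number from compound 1 to compound 4 (0.18 log units; within the scatter), and is expected to stay within the scatter. Compound 4 is expected at 620 nM, with an estimated range of 250 nM to 1500 nM.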

Compound 4, half-maximal inhibitory concentration: 1060 nM
The estimate for compound 4 lay 1.7-fold (0.23 log units) below the measured number, and the stated range covers the measured number.
By their numbers in this assay, from the lowest: compound 1; then compounds 4 and 3 (each within the scatter of the next); then compound 2.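

In this assay, the group of 10 heavy atoms in place of the group of 11 heavy atoms, on a saturated chain carbon, five bonds along the chain from an amine nitrogen in a ring, gives a 2.6-fold higher number from compound 1 to compound 4 (0.41 log units; beyond the scatter). This is the first step among the compounds shown that differ in one place, and it shows that a change of this size at this position moves the number beyond the scatter. Nothing available bears on the reason for this step.

As far as these compounds go, a single step sets no trend, so it remains open whether a longer chain at this place would give a lower number than compound 1 does. Also open, from the compounds shown here alone, is how an amine or a carboxylic acid on this chain would move the number in this assay.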